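Bromo exchanged for methoxy on an aromatic carbon

The compounds below may be only part of what the source reports. "The series", "measured", "known", "first", "only" and "open" are said of these compounds alone.

Among the measured compounds shown here, compound 2 `Cc1n[nH]c2ccc(-c3nc4cnc(N5CCN(C)CC5)cn4c3Nc3ccc(Br)cc3)cc12` is the only compound with a number in a functional assay on CWR22R cells (Homo sapiens) for inhibition, with a stated time of 120 h, tested at 10 uM; a higher number here means more inhibition at the concentration tested (going by the name of the read-out), a lower number less inhibition: compound 2 gives 11.7%. Compound 1 `Cc1n[nH]c2ccc(-c3nc4cnc(N5CCN(C)CC5)cn4c3Nc3ccccc3Cl)cc12` carries no result in this assay, reported as "not determined" (no result reported). Compound 3 `COc1ccc(Nc2c(-c3ccc4[nH]nc(C)c4c3)nc3cnc(N4CCN(C)CC4)cn23)cc1` differs from compound 2 by methoxy in place of bromo on an aromatic carbon. No pair of measured compounds shows how this assay responds to such a change, and no direction can be drawn from the numbers shown. The step of a number 3.3 percentage points higher from compound 2 to compound 3 (within the scatter) is expected to stay within the usual scatter. Compound 3 is estimated at 15%, in a range from 0% to 35%.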

Compound 3, a percentage reported as inhibition, at one concentration (the size of the read-out at that concentration, not a potency): 0%
Beside the measured number, compound 3's estimate is 15 percentage points above it; low and high end bracket the measured number.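

Methoxy in place of bromo on the aromatic carbon para to a large group gives a number 11.7 percentage points lower from compound 2 to compound 3 (beyond the scatter) in this assay. This first readable step shows that the position responds to this change, and that the small inhibition seen with the 4-bromophenyl group does not carry over to the 4-methoxyphenyl group. Nothing available explains this step. On these data alone, what an amine or a carboxylic acid on this same carbon would give stays open. Compound 1 has no number, so it cannot be set against either compound.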